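Capping the remaining hydroxy of compound 2 with methoxymethyl

The source may hold more compounds than are shown below. What is called first, only, known or untested is meant among the compounds shown, and "the series" means these compounds.

Measured compounds:
compound 1 `Oc1ccc(-c2nc3cc(F)ccc3s2)cc1O`: 13000 nM
compound 2 `COc1cc(-c2nc3cc(F)ccc3s2)ccc1O`: 47300 nM
compound 3 `COc1cc(-c2nc3cc(F)ccc3s2)cc(OC)c1OC`: 13000 nM

In a functional assay on KM12 cells (Homo sapiens) for antiproliferative activity (on this read-out higher numbers stand for weaker inhibition of growth and lower numbers for stronger inhibition of growth), compound 2 gives the highest of the three numbers, set apart from both compound 1 and compound 3 by more than the scatter, while compound 1 and compound 3 stand at the same number. Going by the values given here, the one recorded step, a 3.6-fold higher number from compound 1 to compound 2 (0.56 log units; beyond the scatter), is the only direct guide: methyl in place of hydrogen on an oxygen on an aromatic ring raised the number modestly. Compound 3, with all three oxygens methylated, sits back at the level of compound 1, so capping oxygens does not move the number in a single direction across these three compounds.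

Compound 4 `COCOc1ccc(-c2nc3cc(F)ccc3s2)cc1OC` carries the change (methoxymethyl in place of hydrogen on an oxygen on an aromatic ring). Among the compounds with values here, the new group is larger than the methyl of the recorded step and has no measured counterpart here, so the expectation is loose. Because compound 3 gives 13000 nM after further capping, the number for compound 4 is expected to stay near compound 2 or fall somewhat, giving an expected step of a 1.6-fold lower number from compound 2 to compound 4 (0.20 log units; within the scatter). Compound 4 is therefore estimated at 30000 nM, within 8000 nM to 100000 nM.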

Compound 4, concentration for 50% growth inhibition: 19300 nM
For compound 4 the middle estimate is 1.6-fold (0.19 log units) above the measured one; the range from low to high includes it.
By their numbers in this assay, from the lowest: compounds 1, 3 and 4 (each within the scatter of the next); then compound 2.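

Working from this assay, the step of a 2.5-fold lower number from compound 2 to compound 4 (0.39 log units; beyond the scatter) shows that the free hydroxy of compound 2 is not required at this position, since capping it with methoxymethyl lowers the number rather than raising it. This runs opposite to the earlier 3.6-fold higher number from compound 1 to compound 2 (0.56 log units; beyond the scatter), so among these single changes, capping a hydroxy on the aromatic ring does not act in one direction; the two steps differ in both the oxygen capped and the capping group. The lower number also shows that this oxygen tolerates a substituent larger than a methyl, though the step is modest, and no evidence is available to explain its size or direction.

Still open, on these data alone, is whether the step follows from losing the hydroxy hydrogen or from the methoxymethyl group itself, a question that a simple methyl or a longer chain such as methoxyethyl on this same oxygen would help to separate. Also unresolved is how an amine or a carboxylic acid at the end of such a chain would move the number in this assay.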